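Sulfonyl aryl exchange in a benzylamide sulfonamide series

The compounds below may be only part of what the source reports. "The series", "measured", "known", "first", "only" and "open" are said of these compounds alone.

Measured so far:
compound 1 `O=C(NCc1ccc(CNS(=O)(=O)c2ccc([N+](=O)[O-])cc2)cc1)c1cccnc1` gives 100 nM in an assay on MDA-MB-231 cells for displacement of a labelled ligand from C-X-C chemokine receptor type 4 (Homo sapiens), read by fluorescence and microscopy, with stated times of 10 min and 30 min; a higher number here means that more compound is needed for the effect, a lower number that less compound is needed
compound 2 `Cc1ccccc1C(=O)NCc1ccc(CNS(=O)(=O)c2ccccc2F)cc1` gives 1000 nM in this assay

Compound 2 carries the highest number of the two in this assay; compound 1 is its nearest neighbour, with a lower number beyond the scatter. The two differ in more than one place, so their values alone say nothing about either change on its own.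

Compound 3 `Cc1ccccc1C(=O)NCc1ccc(CNS(=O)(=O)c2ccc([N+](=O)[O-])cc2)cc1` takes one change from compound 2: 4-nitrophenyl in place of 2-fluorophenyl on a sulfonyl sulfur. Among the compounds with values here, no measured pair isolates this change. Since compound 1, which also carries the 4-nitrophenyl on the sulfonyl sulfur, gives 100 nM, a lowering of the number from compound 2 to compound 3 of the size a 3.3-fold lower number from compound 2 to compound 3 (0.52 log units; beyond the scatter) is expected in this assay. Compound 3 is estimated at 300 nM, with a range from 80 nM to 1200 nM.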

Compound 3, effective concentration (reported as EC, without a stated level of effect): 100 nM
Beside the measured number, compound 3's estimate is 3.0-fold (0.48 log units) above it; measured number inside the range.
By their numbers in this assay, from the lowest: compounds 1 and 3 (each within the scatter of the next); then compound 2.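

In this assay the exchange of 2-fluorophenyl for 4-nitrophenyl on a sulfonyl sulfur is now isolated and gives a 10-fold lower number from compound 2 to compound 3 (1.00 log units; beyond the scatter) with 2-methylphenyl held on the carbonyl carbon. With 4-nitrophenyl held on the sulfonyl sulfur, 2-methylphenyl in place of pyridin-3-yl on a carbonyl carbon gives no change at the digits printed from compound 1 to compound 3 (within the scatter) in this pair. No measured evidence accounts for either step.

As far as these compounds go, whether the sulfonyl exchange gives a similar step with pyridin-3-yl on the carbonyl carbon remains open. So does the outcome of an amine or a carboxylic acid in place of the nitro group on that phenyl ring.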